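Permeability of Two Catechol Pairs Across an Artificial Membrane

A few compounds are considered here, and "the series" means these few. Any claim that something is new, unique, unknown or untested is made for them only; others in the source may bear on it.

Measured compounds:
- compound 1, `O=S(=O)(/C=C/c1ccc(O)c(O)c1)Cc1ccc(C(F)(F)F)cc1`, 4.3 10^-6 cm/s
- compound 2, `COc1ccc(CS(=O)(=O)/C=C/c2ccc(O)c(O)c2)cc1`, 6.4 10^-6 cm/s
- compound 3, `[O-][S+](/C=C/c1ccc(O)c(O)c1)Cc1ccc(C(F)(F)F)cc1`, 4.2 10^-6 cm/s

Three compounds have been examined in a physicochemical assay for permeability, using PAMPA, with a stated time of 18 h, tested at 5 mg/mL; a lower number here means that the compound crosses the layer more slowly, a higher number that the compound crosses the layer faster. Compound 1 has the structure `O=S(=O)(/C=C/c1ccc(O)c(O)c1)Cc1ccc(C(F)(F)F)cc1` and gives 4.3 10^-6 cm/s in this assay. Compound 2 has the structure `COc1ccc(CS(=O)(=O)/C=C/c2ccc(O)c(O)c2)cc1` and gives 6.4 10^-6 cm/s. Compound 3 has the structure `[O-][S+](/C=C/c1ccc(O)c(O)c1)Cc1ccc(C(F)(F)F)cc1` and gives 4.2 10^-6 cm/s. The difference between the core of compound 1 and the core of compound 3 is not broken down here.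

Compound 2 differs from compound 1 in one place: methoxy in place of trifluoromethyl on an aromatic carbon. This change gave a 1.5-fold higher number from compound 1 to compound 2 (0.17 log units; within the scatter), so the two numbers are within the usual scatter of each other.

Compound 4, with the structure `COc1ccc(C[S+]([O-])/C=C/c2ccc(O)c(O)c2)cc1`, has not yet been measured. It differs from compound 3 by methoxy in place of trifluoromethyl on an aromatic carbon, the same kind of change as that from compound 1 to compound 2, and the place is described in the same words: on an aromatic carbon of a six-membered aromatic ring of carbon only, para to a large group.

The expectation for compound 4 rests on that single earlier step. Since the change from compound 1 to compound 2 gave a 1.5-fold higher number from compound 1 to compound 2 (0.17 log units; within the scatter), a step of similar size is expected here, namely a 1.5-fold higher number from compound 3 to compound 4 (0.17 log units; within the scatter). Compound 4 is therefore expected to give about 6.2 10^-6 cm/s in this assay, with a likely range from 3.5 10^-6 cm/s to 11 10^-6 cm/s.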

Compound 4, apparent permeability: 4.3 10^-6 cm/s
Estimate against measurement, compound 4: 1.4-fold (0.16 log units) above; measured number inside the range.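

Methoxy in place of trifluoromethyl on an aromatic carbon gave a 1.0-fold higher number from compound 3 to compound 4 (0.01 log units; within the scatter) in this assay and, on the other core, a 1.5-fold higher number from compound 1 to compound 2 (0.17 log units; within the scatter). Both steps lie within the scatter, so on these two cores the change left each pair of numbers indistinguishable, and that is the full extent of what carries over; with one pair per core, this does not show that the change would stay within the scatter on a further core, nor does it separate the two steps from each other. Nothing measured here accounts for the result, and no explanation of it can be offered.

The compounds shown hold only trifluoromethyl and methoxy on that aromatic carbon, so it remains open whether an amine, a carboxylic acid or a longer chain in the same place would give a step beyond the scatter, and whether such a step would be alike on both cores. It also remains open whether the same change would stay within the scatter on a core other than the two shown here, or at another place on the aromatic ring.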